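Dihydropyridine esters: swapping a nitrate-bearing chain for isopropyl

A few compounds are considered here, and "the series" means these few. Any claim that something is new, unique, unknown or untested is made for them only; others in the source may bear on it.

Measured compounds:
compound 1 `CC1=C(C(=O)O[C@@H](C)CO[N+](=O)[O-])[C@H](c2cccc3nonc23)C([N+](=O)[O-])=C(C)C1`: 9430 nM
compound 2 `CC1=C(C(=O)OCC(C)O[N+](=O)[O-])C(c2cccc3nonc23)C([N+](=O)[O-])=C(C)C1`: 1700 nM

In a functional assay (ileum) for antagonist activity, with Cavia porcellus as the target (on this read-out lower numbers stand for stronger inhibition and higher numbers for weaker inhibition), compound 2 gives 1700 nM, the lowest of the two numbers; compound 1 gives 9430 nM, a higher number and beyond the scatter. Compound 3 `CC1=C(C(=O)OC(C)C)C(c2cccc3nonc23)C([N+](=O)[O-])=C(C)C1` differs from compound 2 at the ester oxygen: a group of 3 heavy atoms (3 carbon; no ring) in place of a group of 7 heavy atoms (3 carbon, 1 nitrogen, 3 oxygen; no ring), on an oxygen next to a carbonyl group. Among the compounds with values here, no measured pair shows what this change does, so the expected step of a 1.4-fold lower number from compound 2 to compound 3 (0.15 log units; within the scatter) is a guess, small and in either direction. Compound 3 is estimated at 1200 nM, between 250 nM and 6000 nM.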

Compound 3, half-maximal inhibitory concentration: 40 nM
For compound 3 the middle estimate is 30-fold (1.48 log units) above the measured one, and the stated range ends above it.
By their numbers in this assay, from the lowest: compound 3; then compound 2; then compound 1.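

On the ester oxygen, the group strongly sets the result in this assay: replacing the nitrate-bearing chain with isopropyl gives a 43-fold lower number from compound 2 to compound 3 (1.63 log units; beyond the scatter). The nitrate-bearing chain is therefore not needed for inhibition here, and a small plain group on this oxygen does far better. No measurement shown explains this step.

The change removes the nitrate and shortens the chain together, so the two effects cannot be separated. A hydroxypropyl chain or a longer plain carbon chain on this oxygen would help tell them apart.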